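Cyclohexylmethyl ether: expected tolerance in the cytotoxicity screen

This account rests on a few compounds, and the source may have more. Where it says the series, first, only, none or still open, it means among the compounds named here.

Measured so far in an ADME assay on HEL cells (Homo sapiens) for cytotoxicity, with a stated time of 3 days; a higher number here means that more compound is tolerated, a lower number that less compound is tolerated:
- compound 1, `CCC1(Cc2ccccc2)OS(=O)(=O)C=C1OCC#N`, a limit of > 400000 nM
- compound 2, `CCC1(Cc2ccccc2)OS(=O)(=O)C=C1OCc1ccc(F)cc1`, a limit of >= 50000 nM
- compound 3, `CCC1(Cc2ccccc2)OS(=O)(=O)C=C1OCc1ccc(OC)cc1`, a limit of >= 200000 nM

All three values are limits of this assay rather than numbers. Compound 3 sits at the limit of >= 200000 nM in this assay, at which 1 of the 3 values shown sits. The steps between the measured compounds are therefore not readable in size: a step that the two limits leave unreadable from compound 1 to compound 2, a step that the two limits leave unreadable from compound 1 to compound 3 and a step that the two limits leave unreadable from compound 2 to compound 3. Compound 3 stands at a limit with two further limits beside it, so no direction can be drawn from the measured series.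

Compound 4, `CCC1(Cc2ccccc2)OS(=O)(=O)C=C1OCC1CCCCC1`, is not yet measured. Its difference from compound 3 is cyclohexyl in place of 4-methoxyphenyl on a saturated chain carbon bound to an oxygen on an unsaturated carbon. Only the two steps touching compound 3, each unreadable, bear on this change, so no step beyond the scatter is expected in this assay in either direction, and a further limit is the likelier outcome. The expected step in this assay is a number no higher from compound 3 to compound 4 (the limit leaves the size open). Compound 4 is expected to show about 200000 nM in this assay, with a range from 50000 nM to 400000 nM.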

Compound 4, minimum cytotoxic concentration: >= 200000 nM
Compound 4 ended at the assay's limit; the forecaster's own chance of this, stated with the estimate: 80%; the middle value sits exactly at the limit.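

In this assay compound 4 gives >= 200000 nM, which is a limit. Among these compounds, compound 1, compound 2 and compound 3 also stand at limits, so no step to compound 4 can be read. The compounds shown leave open whether the ether groups differ at all in tolerated concentration.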